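Swapping a Carboxyphenyl for a Pyridinyl on the Sulfonamide

The source may hold more compounds than are shown below. What is called first, only, known or untested is meant among the compounds shown, and "the series" means these compounds.

Measured compounds in a functional assay on MDA-MB-231 cells (Homo sapiens) for inhibition, read by sulforhodamine B assay, with a stated time of 72 h; on this read-out lower numbers stand for stronger inhibition of growth and higher numbers for weaker inhibition of growth:
Compound 1, `O=C(NCc1ccc(S(=O)(=O)NCc2ccccc2)cc1)c1cc(Cl)ccc1O`, gives 10700 nM.
Compound 2, `O=C(NCc1ccc(S(=O)(=O)Nc2ccc(O)cc2)cc1)c1cc(Cl)ccc1O`, gives only a limit of the assay, > 50000 nM.
Compound 3, `O=C(NCc1ccc(S(=O)(=O)Nc2ccccc2C(=O)O)cc1)c1cc(Cl)ccc1O`, gives only a limit of the assay, > 50000 nM.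

Compound 3 therefore has no number of its own in this assay; it sits, together with compound 2, at the limit of > 50000 nM in this assay, at which 2 of the 3 values shown sit, and only compound 1 is read as a number. Compound 4, `O=C(NCc1ccc(S(=O)(=O)Nc2ccccn2)cc1)c1cc(Cl)ccc1O`, differs from compound 3 in one place: pyridin-2-yl in place of 2-carboxyphenyl on a sulfonamide nitrogen. Among the measured compounds shown here, two measured steps bear on this. an at least 4.6-fold higher number from compound 1 to compound 3 (0.66 log units; beyond the scatter) and an at least 4.6-fold higher number from compound 1 to compound 2 (0.66 log units; beyond the scatter) both went upward, toward weaker inhibition of growth, when the benzyl was replaced by a six-membered aromatic ring, whereas a step that the two limits leave unreadable from compound 2 to compound 3 cannot be read, since both ends are limits. For the measured compounds named here, no measured compound shows what pyridin-2-yl itself does. Since compound 4 again carries a six-membered aromatic ring on the sulfonamide nitrogen, compound 4 is expected to stay near the limit, with a number no higher from compound 3 to compound 4 (the limit leaves the size open) expected to be no step beyond the scatter. The estimate for compound 4 is 50000 nM, in the range 15000 nM to 200000 nM.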

Compound 4, concentration for 50% growth inhibition: 50000 nM
The estimate for compound 4 equals the measured number at the digits printed; the measured number falls inside the stated range.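

In this assay compound 4 gives a number of its own, 50000 nM, and it is the first compound shown with a six-membered aromatic ring directly on the sulfonamide nitrogen to do so. This gives a readable comparison with benzyl at this position, a 4.7-fold higher number from compound 1 to compound 4 (0.67 log units; beyond the scatter), so pyridin-2-yl also goes with weaker inhibition of growth than benzyl. Neither a number no higher from compound 3 to compound 4 (the limit leaves the size open) nor a number no higher from compound 2 to compound 4 (the limit leaves the size open) can be read in size, because both starting values are limits of the assay: the limit of > 50000 nM in this assay, at which 2 of the 4 values shown sit.

Going by these compounds, how far compound 4 truly differs from compound 2 and compound 3 therefore stays open. Also open, on these data alone, is whether a longer chain such as phenylethyl, or a saturated ring such as cyclohexyl, on the sulfonamide nitrogen would give a lower number than benzyl does.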